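Benzoyl to carbamoyl on the shared core

The compounds below may be only part of what the source reports. "The series", "measured", "known", "first", "only" and "open" are said of these compounds alone.

In a functional assay on A549 cells (Homo sapiens) for antiproliferative activity, read by MTT assay (on this read-out higher numbers stand for weaker inhibition and lower numbers for stronger inhibition), compound 3 (`O=C(c1ccccc1)N1CCCc2cc(S(=O)(=O)N3CC(c4ccccc4)NC3=O)ccc21`) gives 8140 nM and sits within the scatter of compound 2 (`C=CCOC(=O)N1CCCc2cc(S(=O)(=O)N3CC(c4ccccc4)NC3=O)ccc21`) at 4310 nM on the same read-out. Compound 1 (`CCCCOC(=O)N1CCCc2cc(S(=O)(=O)N3CC(c4ccccc4)NC3=O)ccc21`) stands at > 20000 nM as a limit of the assay, not a number. Compound 4 (`NC(=O)N1CCCc2cc(S(=O)(=O)N3CC(c4ccccc4)NC3=O)ccc21`) differs from compound 3 by amino in place of phenyl on a carbonyl carbon. Two measured steps change the group on that carbonyl carbon (an at least 2.4-fold lower number from compound 1 to compound 3 (0.39 log units; beyond the scatter)) and (a 1.9-fold higher number from compound 2 to compound 3 (0.28 log units; within the scatter)). Neither brings in an amino group, so no step beyond the scatter is expected in this assay, with any drift toward higher numbers. The expected step is (a 1.2-fold higher number from compound 3 to compound 4 (0.09 log units; within the scatter)). The estimate for compound 4 is (10000 nM), with 3500 nM to 20000 nM as the expected range.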

Compound 4, half-maximal inhibitory concentration: 2540 nM
Estimate against measurement, compound 4: 3.9-fold (0.60 log units) above, and the stated range ends above it.
By their numbers in this assay, from the lowest: compounds 4, 2 and 3 (each within the scatter of the next, the first and the last beyond it). At a limit, above all of these: compound 1.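

Replacing phenyl with amino on this carbonyl carbon gives a step beyond the scatter in this assay, a 3.2-fold lower number from compound 3 to compound 4 (0.51 log units; beyond the scatter), so an aromatic ring is not needed there for this activity. Against allyloxy the step stays within the scatter, a 1.7-fold lower number from compound 2 to compound 4 (0.23 log units; within the scatter), so no order can be set between those two groups. Against butoxy the step reads an at least 7.8-fold lower number from compound 1 to compound 4 (0.89 log units; beyond the scatter), and its size is open-ended as compound 1 stands at a limit, not a number: the limit of > 20000 nM in this assay, at which 1 of the 4 values shown sits.

Open, going by these compounds, is how methylamino or dimethylamino on the same carbonyl carbon would read.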